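Swapping chloro for methyl in compound 3

This account rests on a few compounds, and the source may have more. Where it says the series, first, only, none or still open, it means among the compounds named here.

Three close relatives share one core and carry a bromo- or chloro-substituted phenyl group on an oxygen. Compound 1 `O=S(=O)(Oc1ccc(Br)cc1)C1CC2OC1C(c1ccc(/C=C/c3cc(O)cc(O)c3)cc1)=C2c1ccc(O)cc1` gives 16900 nM in a functional assay on MCF7 cells (Homo sapiens) for antiproliferative activity, read by MTT assay, with a stated time of 72 h (on this read-out lower numbers stand for stronger inhibition and higher numbers for weaker inhibition), as a first reference point. Compound 2 `O=S(=O)(Oc1ccc(Cl)cc1)C1CC2OC1C(c1ccc(/C=C/c3cc(O)cc(O)c3)cc1)=C2c1ccc(O)cc1` gives 17900 nM in this assay and compound 3 `O=S(=O)(Oc1cccc(Cl)c1)C1CC2OC1C(c1ccc(/C=C/c3cc(O)cc(O)c3)cc1)=C2c1ccc(O)cc1` gives 12900 nM on the same scale. The steps reaching compound 3 are small (a 1.3-fold lower number from compound 1 to compound 3 (0.12 log units; within the scatter); a 1.4-fold lower number from compound 2 to compound 3 (0.14 log units; within the scatter)). Both stay within the usual scatter, so compound 3 cannot be told apart from the other two. Compound 4 `Cc1cccc(OS(=O)(=O)C2CC3OC2C(c2ccc(/C=C/c4cc(O)cc(O)c4)cc2)=C3c2ccc(O)cc2)c1` carries methyl in place of chloro on an aromatic carbon, meta to a large group (methyl in place of chloro on an aromatic carbon). For the measured compounds named here, no measured step makes this exact swap, so the evidence is indirect. The closest parallel is chloro in place of bromo on an aromatic carbon (a 1.1-fold higher number from compound 1 to compound 2 (0.02 log units; within the scatter)), which also stays within the scatter. Among these three compounds, no change on this phenyl group has moved the number beyond the scatter. A step beyond the scatter is therefore not expected in this assay and neither direction is favoured. The expected step is small by this estimate (a 1.1-fold higher number from compound 3 to compound 4 (0.04 log units; within the scatter)). Compound 4 is expected to read 14000 nM (estimated range 8000 nM to 24000 nM).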

Compound 4, half-maximal inhibitory concentration: 16300 nM
Beside the measured number, compound 4's estimate is 1.2-fold (0.07 log units) below it; low and high end bracket the measured number.
By their numbers in this assay, from the lowest: compounds 3, 4, 1 and 2 (each within the scatter of the next).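

In this assay, the direct swap of chloro for methyl on an aromatic carbon, meta to a large group, gives a 1.3-fold higher number from compound 3 to compound 4 (0.10 log units; within the scatter) and so shows that a carbon can replace the chlorine here with no difference that can be told from repeat measurements. The comparisons with the other two compounds agree: 3-methylphenyl in place of 4-chlorophenyl gives a 1.1-fold lower number from compound 2 to compound 4 (0.04 log units; within the scatter) and 3-methylphenyl in place of 4-bromophenyl gives a 1.0-fold lower number from compound 1 to compound 4 (0.02 log units; within the scatter) so compound 4, the only one of the four whose phenyl group carries no halogen, cannot be separated from any of the halogen-bearing compounds. Nothing available explains why these four numbers sit so close together.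

Chloro, bromo and methyl alone cannot show whether this phenyl group has any real influence on the number, so it stays open whether a hydroxyl, an amine or a carboxylic acid in this place would produce a step beyond the scatter. Also open, on these data alone, is how a plain phenyl group with no substituent, or a longer chain such as butyl on the ring, would compare with compound 4.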